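The source may report more compounds than this note shows. Statements on the series, on what has been measured and on what is new or still open speak of the compounds shown alone.

Going by the values given here, in a functional assay on the whole organism with Rattus norvegicus as the target (a lower number here means that less compound is needed, a higher number that more compound is needed for the effect), compound 3 `O=C(O)C(=O)Nc1nc(-c2cc(-c3ccccc3)on2)cs1` gives 2.6 mg/kg, the lowest of the three numbers so far, against compound 1 `CCOCCOC(=O)C(=O)Nc1nc(-c2cc(CO)on2)cs1` at 14 mg/kg and compound 2 `Cc1cc(-c2csc(NC(=O)C(=O)O)n2)no1` at 17 mg/kg. Compound 4 `O=C(O)C(=O)Nc1nc(-c2cc(CO)on2)cs1` has hydroxymethyl in place of phenyl on an aromatic carbon. Among the compounds with values here, the one measured step at this place is a 6.5-fold lower number from compound 2 to compound 3 (0.82 log units; beyond the scatter), with phenyl in place of methyl, so losing phenyl should move this assay the opposite way by a similar amount, beyond the scatter. Compound 1 also bears hydroxymethyl, though it differs elsewhere, and gives 14 mg/kg. The expected step is a 5.0-fold higher number from compound 3 to compound 4 (0.70 log units; beyond the scatter), towards a higher number. For compound 4 the estimated value is 13 mg/kg, with an expected range of 5 mg/kg to 32 mg/kg.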

Compound 4, dose for half-maximal effect: > 30 mg/kg
Compound 4: no number, only a limit (the forecaster's own chance of this, stated with the estimate: 5%); middle value at least 2.3-fold (0.36 log units) from the limit.
By their numbers in this assay, from the lowest: compound 3; then compounds 1 and 2 (each within the scatter of the next). At a limit, above all of these: compound 4.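

In this assay compound 4 has no number, only a limit: the limit of > 30 mg/kg in this assay, at which 1 of the 4 values shown sits. Even read as a floor, hydroxymethyl in place of phenyl next to the ring oxygen gives an at least 11-fold higher number from compound 3 to compound 4 (1.06 log units; beyond the scatter), so of the groups shown at this place, phenyl alone goes with the lowest number. Hydroxy added to the methyl group gives an at least 1.7-fold higher number from compound 2 to compound 4 (0.24 log units; that floor lies within the scatter), a floor that leaves those two compounds unseparated, while hydrogen in place of 2-ethoxyethyl gives an at least 2.1-fold higher number from compound 1 to compound 4 (0.33 log units; beyond the scatter).

On these data alone, how far compound 4 lies past its limit stays open. So does whether an aminomethyl group or a longer alkyl chain at this place would give a number as low as that of compound 3.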